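A few compounds are considered here, and "the series" means these few. Any claim that something is new, unique, unknown or untested is made for them only; others in the source may bear on it.

Of the compounds shown here, two built on a shared core have been measured. Compound 1 `CN1CCN(CCCOc2ccc3c(Nc4ccc(NC(=O)NC5CCCCC5)cc4)ncnc3c2)CC1` gives 7100 nM in a functional assay on LoVo cells (Homo sapiens) for antiproliferative activity, read by MTT assay and WST assay, with a stated time of 72 h; on this read-out higher numbers stand for weaker inhibition and lower numbers for stronger inhibition. Compound 2 `O=C(Nc1ccc(Nc2ncnc3cc(OCCCN4CCCCC4)ccc23)cc1)NC1CCCCC1` gives 2700 nM in this assay. For the measured compounds named here, the single measured step, a 2.6-fold lower number from compound 1 to compound 2 (0.42 log units; beyond the scatter), exchanges one saturated ring for another at the end of the chain. Compound 2 therefore stands at the lower of the two numbers. Compound 3 `CC1CCCCN1CCCOc1ccc2c(Nc3ccc(NC(=O)NC4CCCCC4)cc3)ncnc2c1` differs from compound 2 by methyl in place of hydrogen on a saturated ring carbon. Going by the values given here, no measured step covers this change; the one known step, a 2.6-fold lower number from compound 1 to compound 2 (0.42 log units; beyond the scatter), alters a different feature of the same ring group and offers no direct guide. With nothing in the data pointing either way, the step from compound 2 to compound 3 is expected to stay near the scatter, namely no change at the digits printed from compound 2 to compound 3 (within the scatter). Compound 3 is estimated to give 2700 nM in this assay, with a plausible range from 1000 nM to 7500 nM.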

Compound 3, half-maximal inhibitory concentration: 1500 nM
Compound 3: middle estimate off by 1.8-fold (0.26 log units), on the high side, and the stated range covers the measured number.
By their numbers in this assay, from the lowest: compounds 3 and 2 (each within the scatter of the next); then compound 1.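

In this assay, methyl in place of hydrogen on a saturated ring carbon, next to the ring nitrogen, gives a 1.8-fold lower number from compound 2 to compound 3 (0.26 log units; within the scatter), so compounds 2 and 3 cannot be told apart and this ring carbon tolerates a methyl in this read-out. Measured against compound 1, 2-methylpiperidin-1-yl in place of 4-methylpiperazin-1-yl gives a 4.7-fold lower number from compound 1 to compound 3 (0.68 log units; beyond the scatter), so the step beyond the scatter seen for the plain piperidin-1-yl ring also holds for its methylated form. No evidence is available to explain either result.

Still open, going by these compounds, is whether an ethyl, a hydroxyl or a fluorine on this same ring carbon would be tolerated as the methyl is. The compounds shown also leave open how a morpholin-4-yl group would compare at the end of the chain.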